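The source may hold more compounds than are shown below. What is called first, only, known or untested is meant among the compounds shown, and "the series" means these compounds.

In an ADME assay on HEK293 cells (Homo sapiens) for cytotoxicity, with a stated time of 72 h (on this read-out lower numbers stand for an effect already at smaller amounts and higher numbers for an effect only at larger amounts of compound), compound 1 (`CSc1ccc(NC(=O)Nc2cc(C)nc3ccccc23)cc1`) gives 24000 nM. Compound 2 (`CC(=O)c1ccc(NC(=O)Nc2cc(C)nc3ccccc23)cc1`) gives > 25000 nM, which is a limit of the assay and not a number. Compound 2 therefore has no exact position, only (the limit of > 25000 nM in this assay, at which 1 of the 2 values shown sits).

Compound 3 (`Cc1ccc(NC(=O)Nc2cc(C)nc3ccccc23)cc1`) keeps the shared core and changes one group: methyl in place of acetyl on an aromatic carbon. This puts methyl in place of acetyl on an aromatic carbon, para to a large group.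

For the measured compounds named here, one measured step bears on this change, as it alters the group at the same place: an at least 1.0-fold higher number from compound 1 to compound 2 (0.01 log units; that floor lies within the scatter). This is a single step, and it does not show how methyl will behave. Compound 1 gives 24000 nM with methylsulfanyl at this place, so a number in the same region is expected for compound 3. Compound 3 may also give a limit reading.

No step beyond the scatter is expected in this assay. The estimated change is an at least 1.1-fold lower number from compound 2 to compound 3 (0.05 log units; that floor lies within the scatter). For compound 3 the expected value is 22000 nM, with an estimated range of 12000 nM to 35000 nM.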

Compound 3, half-maximal effective concentration: > 25000 nM
Compound 3 was reported as a limit; the forecaster's own chance of this, stated with the estimate: 40%; middle value at least 1.1-fold (0.05 log units) from the limit.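

In this assay, compound 3 is now a second compound reported only as a limit of the assay, so the step between the two limit readings, with methyl or acetyl on the aromatic carbon para to a large group, cannot be read. Methyl in place of methylsulfanyl gives an at least 1.0-fold higher number from compound 1 to compound 3 (0.01 log units; that floor lies within the scatter), and since this is only a floor, the true size of the step remains unknown, though the change is not shown to lower the number. With three groups now seen at this place, methylsulfanyl, acetyl and methyl, compound 1 alone gives an exact number, and the other two readings stop at the same limit: the limit of > 25000 nM in this assay, at which 2 of the 3 values shown sit.

As far as these compounds go, it remains open how far the true values of compound 2 and compound 3 lie past that limit, and so whether these two differ at all. From the compounds shown here alone, it is also open whether an amine or a carboxylic acid at this aromatic carbon would give a reading that can be placed as an exact number against compound 1.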